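Glucagon receptor series: varying the aryl on the ring nitrogen

A few compounds are considered here, and "the series" means these few. Any claim that something is new, unique, unknown or untested is made for them only; others in the source may bear on it.

Measured so far:
compound 1, `CCCC(Oc1cnn(-c2cccc(C)c2)c1)c1ccc(C(=O)NCCC(=O)O)cc1`, in an assay on isolated protein for displacement of a labelled ligand from Glucagon receptor (Homo sapiens) (a lower number here means a stronger inhibitor, a higher number a weaker inhibitor), compound 1 gives 1110 nM
compound 2, `CCCC(Oc1cnn(-c2cccc(Cl)c2)c1)c1ccc(C(=O)NCCC(=O)O)cc1`, in this assay compound 2 gives 1090 nM
compound 3, `CCCC(Oc1cnn(-c2cccc(CC)c2)c1)c1ccc(C(=O)NCCC(=O)O)cc1`, in this assay compound 3 gives 556 nM

Compound 3 carries the lowest of the three numbers, but the steps of a 2.0-fold lower number from compound 1 to compound 3 (0.30 log units; within the scatter) and a 2.0-fold lower number from compound 2 to compound 3 (0.29 log units; within the scatter) both stay within the scatter, so the three compounds cannot be ranked against each other. Compound 4, `CCCC(Oc1cnn(-c2ccc(Cl)cc2)c1)c1ccc(C(=O)NCCC(=O)O)cc1`, introduces (4-chlorophenyl in place of 3-ethylphenyl on an aromatic nitrogen). Within the data shown here, two measured steps bear on this change: a 2.0-fold lower number from compound 2 to compound 3 (0.29 log units; within the scatter) exchanges ethyl and chloro on the same aryl, and a 1.0-fold lower number from compound 1 to compound 2 (0.01 log units; within the scatter) exchanges methyl and chloro there; both are within the scatter. Among the measured compounds shown here, no measured pair compares a 3-substituted aryl with a 4-substituted aryl directly, so that part of the change is untested here. The expectation is therefore a step of a 1.7-fold higher number from compound 3 to compound 4 (0.23 log units; within the scatter) that, if anything, returns toward the number of compound 2 and stays within the scatter. Compound 4 is estimated at 950 nM, with a range from 400 nM to 2500 nM.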

Compound 4, inhibition constant: 600 nM
For compound 4 the middle estimate is 1.6-fold (0.20 log units) above the measured one; the measured number falls inside the stated range.
By their numbers in this assay, from the lowest: compounds 3, 4, 2 and 1 (each within the scatter of the next).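

Among these compounds, with chloro kept on the aryl, the change from 3-chlorophenyl to 4-chlorophenyl gives the first direct comparison of the two substitution patterns on this aromatic nitrogen (a 1.8-fold lower number from compound 2 to compound 4 (0.26 log units; within the scatter)), and that step is within the scatter. The other two steps (a 1.1-fold higher number from compound 3 to compound 4 (0.03 log units; within the scatter) and a 1.9-fold lower number from compound 1 to compound 4 (0.27 log units; within the scatter)) are also within the scatter, so in this assay the four aryl groups cannot be ranked and neither substitution pattern is set apart by these compounds. No supporting data bear on the reason for this result.

Still open, on these data alone, is whether 4-methylphenyl and 4-ethylphenyl would also stay within the scatter of their 3-substituted counterparts. Also open, as far as these compounds go, is whether an amine, a carboxylic acid or a longer chain on this aryl would produce a step beyond the scatter.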